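A few compounds are considered here, and "the series" means these few. Any claim that something is new, unique, unknown or untested is made for them only; others in the source may bear on it.

In a functional assay on A-375 cells (Homo sapiens) for cytotoxicity, read by MTT assay, with a stated time of 72 h (on this read-out higher numbers stand for weaker inhibition and lower numbers for stronger inhibition), three compounds built on one shared core have been measured so far. Compound 1 `O=C1c2c[n+]([O-])c3ccccc3c2C(=O)c2c1c1ccccc1n2Cc1cn([C@H]2O[C@H](CO)[C@@H](O)[C@H]2O)nn1` gives 340 nM, compound 2 `O=C1c2c[n+]([O-])c3ccccc3c2C(=O)c2c1c1ccccc1n2CCN1CCCC1` gives 430 nM, and compound 3 `O=C1c2c[n+]([O-])c3ccccc3c2C(=O)c2c1c1ccccc1n2Cc1cn([C@@H]2O[C@H](CO)[C@@H](O)[C@H](O)[C@H]2O)nn1` gives 230 nM. Within the data shown here, of these three numbers the one for compound 2 is the highest, yet its distance from compound 1 and from compound 3 lies within the usual scatter, so the three compounds are not really separated by these measurements.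

Compound 4 `O=C1c2c[n+]([O-])c3ccccc3c2C(=O)c2c1c1ccccc1n2CCN1CCCCC1` has not yet been measured. It differs from compound 2 in a single place: piperidin-1-yl in place of pyrrolidin-1-yl on a saturated chain carbon, two bonds along the chain from an aromatic nitrogen. Among the measured compounds shown here, the only measured step between compounds differing in one place, a 1.5-fold lower number from compound 1 to compound 3 (0.17 log units; within the scatter), concerns the ring attached to an aromatic nitrogen and says nothing about the ring at the end of the saturated chain. No measured pair changes that ring, so nothing shown points to a shift in either direction. The step of no change at the digits printed from compound 2 to compound 4 (within the scatter) is therefore expected to stay within the scatter. The estimate for compound 4 is 430 nM, within a range from 200 nM to 900 nM.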

Compound 4, half-maximal inhibitory concentration: 180 nM
Beside the measured number, compound 4's estimate is 2.4-fold (0.38 log units) above it, and the stated range ends above it.
By their numbers in this assay, from the lowest: compounds 4, 3, 1 and 2 (each within the scatter of the next, the first and the last beyond it).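

In this assay, the ring at the end of the saturated chain turns out to matter: going from pyrrolidin-1-yl to piperidin-1-yl gives a 2.4-fold lower number from compound 2 to compound 4 (0.38 log units; beyond the scatter) and so separates two compounds, though only modestly. The only other single-place change shown concerns the ring on an aromatic nitrogen and stays within the scatter, so this chain end is the one place here where a small change in one group clearly moves the number. No measurement shown accounts for this shift.

A single pair cannot say whether the number keeps falling as this ring grows or whether the six-membered ring is a special case. Going by these compounds, the seven-membered azepan-1-yl ring, morpholin-4-yl, an open-chain diethylamino group and a longer chain leading to the piperidine remain open.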